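Swapping a cyclobutyl for a neopentyl on the ring nitrogen

This account rests on a few compounds, and the source may have more. Where it says the series, first, only, none or still open, it means among the compounds named here.

In a functional assay on the whole organism for inhibition, with Nicotiana tabacum as the target (on this read-out lower numbers stand for stronger inhibition and higher numbers for weaker inhibition), compound 1 `Cc1nc2nccc-2c(NC(C)C)[nH]1` gives 550000000 nM. Compound 2 `Cc1nc(NC2CCC2)c2cc[nH]c2n1` gives 74100000 nM in this assay, the lowest of the two numbers and beyond the scatter from compound 1. Compound 3 `Cc1nc(NCC(C)(C)C)c2cc[nH]c2n1` differs from compound 2 by one change: neopentyl in place of cyclobutyl on a nitrogen on an aromatic ring. For the measured compounds named here, no measured pair shows what such a change does here, so only a small shift, within the scatter and in no clear direction, is expected from compound 2 to compound 3, namely a 1.1-fold higher number from compound 2 to compound 3 (0.03 log units; within the scatter). For compound 3 the estimate in this assay is 80000000 nM, ranging from 25000000 nM to 250000000 nM.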

Compound 3, half-maximal inhibitory concentration: 200000000 nM
The estimate for compound 3 lay 2.5-fold (0.40 log units) below the measured number, within the range that was stated.
By their numbers in this assay, from the lowest: compound 2; then compound 3; then compound 1.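

In this assay the neopentyl, which has no ring, does not do as well as the cyclobutyl on this nitrogen (a 2.7-fold higher number from compound 2 to compound 3 (0.43 log units; beyond the scatter)), a modest weakening that lies beyond the scatter. For the compounds shown here, this is the first pair differing in one place, and it shows that the group on this nitrogen can shift the read-out. Nothing measured here explains the shift. Still open, going by these compounds, is how other groups on this nitrogen would behave, such as a cyclopentyl ring, a straight butyl chain or a carboxylic acid.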